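This account rests on a few compounds, and the source may have more. Where it says the series, first, only, none or still open, it means among the compounds named here.

Series notes

Compound 1 `Oc1ccc(/C=C/c2cc(O)ccc2O)cc1`: 9600 nM
Compound 2 `Oc1cccc(/C=C/c2cc(O)ccc2O)c1`: 10500 nM

Both values come from an ADME assay on NIH3T3 cells (Mus musculus) for cytotoxicity, read by colorimetric assay and sulforhodamine B assay, with a stated time of 96 h; a lower number here means a stronger inhibitor, a higher number a weaker inhibitor. Compound 2 stands at 10500 nM, within the scatter of compound 1 at 9600 nM, so the two cannot be ordered. Compound 3 `Oc1ccc(O)c(/C=C/c2ccc(O)c(O)c2)c1` is reached from compound 2 by one change, hydroxy in place of hydrogen on an aromatic carbon, ortho to a hydroxy group and para to a large group. For the measured compounds named here, the data hold no measured step for adding a hydroxy, so the expectation below is a tentative judgement. A moderate move toward a lower number, beyond the scatter, is expected, though no change beyond the scatter remains possible. The expected step is a 2.1-fold lower number from compound 2 to compound 3 (0.32 log units; beyond the scatter). In this assay, the estimated value for compound 3 is 5000 nM, with an expected range from 1800 nM to 12000 nM.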

Compound 3, half-maximal inhibitory concentration: > 30000 nM
Compound 3 gave a limit, no number; the forecaster's own chance of this, stated with the estimate: 3%; at least 6.0-fold (0.77 log units) between middle value and limit.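

Compounds 1 and 2 could not be ordered, so moving the hydroxy on that ring gave no readable difference; adding a hydroxy to that ring does. Hydroxy in place of hydrogen on an aromatic carbon, ortho to a hydroxy group and para to a large group, gives an at least 2.8-fold higher number from compound 2 to compound 3 (0.45 log units; beyond the scatter) in this assay, and the same compound reached from the other side gives an at least 3.1-fold higher number from compound 1 to compound 3 (0.49 log units; beyond the scatter). Both steps point toward a weaker inhibitor, and the true size of each stays unread because compound 3 sits at a limit and not at a number: the limit of > 30000 nM in this assay, at which 1 of the 3 values shown sits.

Going by these compounds, whether a methoxy group or an amine at this same place would move the number in the same direction stays open. So does whether the shift needs the neighbouring hydroxy group or comes from the added hydroxy alone.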